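Trading a Fluorinated Benzyl Group for a Methoxyphenyl Group

A few compounds are considered here, and "the series" means these few. Any claim that something is new, unique, unknown or untested is made for them only; others in the source may bear on it.

Compound 3 `COc1ccc2c(=O)c(/C=C/C(=O)NCc3ccccc3F)coc2c1` is one of three amides that share a core and differ only in the group on the amide nitrogen. In a functional assay on A549 cells (Homo sapiens) for inhibition, read by MTT assay, with a stated time of 48 h (a lower number here means a stronger inhibitor, a higher number a weaker inhibitor), compound 3 gives only a limit, > 100000 nM, so no number is known for it. Its two comparators are measured: compound 1 `COc1ccc(CNC(=O)/C=C/c2coc3cc(OC)ccc3c2=O)cc1` gives 22500 nM, and compound 2 `COc1ccc2c(=O)c(/C=C/C(=O)NCc3ccccc3)coc2c1` gives 11800 nM. The difference between them is a 1.9-fold lower number from compound 1 to compound 2 (0.28 log units; within the scatter). The steps onto compound 3 are larger: an at least 4.4-fold higher number from compound 1 to compound 3 (0.64 log units; beyond the scatter) and an at least 8.4-fold higher number from compound 2 to compound 3 (0.92 log units; beyond the scatter). As far as these compounds go, because compound 3 sits at the limit of > 100000 nM in this assay, at which 1 of the 3 values shown sits, the true size of those steps is unknown.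

Compound 4 `COc1cccc(NC(=O)/C=C/c2coc3cc(OC)ccc3c2=O)c1` is the unmeasured compound. 3-methoxyphenyl in place of 2-fluorobenzyl on an amide-type nitrogen Two things change at once: the fluoro goes, and the aromatic ring now sits directly on the amide nitrogen rather than on a saturated chain carbon. Nothing measured here isolates that second change. The step of an at least 8.4-fold higher number from compound 2 to compound 3 (0.92 log units; beyond the scatter) shows that removing the fluoro should lower the number, so compound 4 is expected to land nearer compound 1 and compound 2 than compound 3, an estimated step of an at least 3.3-fold lower number from compound 3 to compound 4 (0.52 log units; beyond the scatter). The estimate for compound 4 in this assay is 30000 nM, with a range from 8000 nM to 100000 nM.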

Compound 4, half-maximal inhibitory concentration: 12800 nM
Compound 4: the middle estimate sits 2.3-fold (0.37 log units) above what was measured, and the stated range covers the measured number.
By their numbers in this assay, from the lowest: compounds 2, 4 and 1 (each within the scatter of the next). At a limit, above all of these: compound 3.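

On an amide-type nitrogen, a 3-methoxyphenyl group performs in this assay much like the benzyl and 4-methoxybenzyl groups, as a 1.1-fold higher number from compound 2 to compound 4 (0.04 log units; within the scatter) and a 1.8-fold lower number from compound 1 to compound 4 (0.24 log units; within the scatter) show. The aromatic ring can therefore sit on that nitrogen itself, without the saturated chain carbon that the two benzyl groups carry, and the number stays within the scatter of theirs, while the 2-fluorobenzyl group alone stands apart among the four, with an at least 7.8-fold lower number from compound 3 to compound 4 (0.89 log units; beyond the scatter) on leaving it. That step is only a minimum because compound 3 gives a limit and not a number: the limit of > 100000 nM in this assay, at which 1 of the 4 values shown sits.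

The compounds shown leave open whether the break at compound 3 comes from the fluoro itself or from the place it holds on the ring, and a 3-fluorobenzyl or 4-fluorobenzyl group would speak to that. They also leave open how the methoxy place and the chain carbon each count separately, which a 3-methoxybenzyl group or an unsubstituted phenyl group on the same nitrogen would help to separate, and whether a longer chain such as phenethyl would fit as well.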